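A few compounds are considered here, and "the series" means these few. Any claim that something is new, unique, unknown or untested is made for them only; others in the source may bear on it.

In a functional assay on HepG2 cells (Homo sapiens) for cytotoxicity, with a stated time of 72 h (a higher number here means that more compound is needed for the effect, a lower number that less compound is needed), compound 1 `C=C[C@@](C)(/C=C/c1ccc(OS(=O)(=O)C(F)(F)F)cc1)CCC=C(C)C` gives > 52000 nM as a limit and not a number. Compound 2 `C=C[C@@](C)(/C=C/c1ccc(Nc2ccc(F)c(F)c2)cc1)CCC=C(C)C` gives > 52000 nM as a limit as well. Compound 3 `C=C[C@@](C)(/C=C/c1ccc(Nc2ccc(Cl)cc2)cc1)CCC=C(C)C` gives > 52000 nM as a limit too and has no number of its own. Compound 3 thus stands at the limit of > 52000 nM in this assay, at which 3 of the 3 values shown sit, in this short series.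

Compound 4 `C=C[C@@](C)(/C=C/c1ccc(-c2cccc(F)c2)cc1)CCC=C(C)C` carries 3-fluorophenyl in place of (4-chlorophenyl)amino on an aromatic carbon, para to a large group (3-fluorophenyl in place of (4-chlorophenyl)amino on an aromatic carbon). The measured steps that bear on this exchange are a step that the two limits leave unreadable from compound 1 to compound 2 together with a step that the two limits leave unreadable from compound 1 to compound 3 and a step that the two limits leave unreadable from compound 2 to compound 3 and none of them has a readable size. All three compounds sit at the same limit, so no step beyond the scatter and no direction can be expected in this assay for this exchange. The expected outcome is a step that the limit leaves unreadable from compound 3 to compound 4 as an estimate only. Compound 4 is estimated at 55000 nM with an expected range from 25000 nM to 100000 nM and a report as a limit alone is likely.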

Compound 4, half-maximal effective concentration: > 52000 nM
Compound 4 was reported as a limit; the forecaster's own chance of this, stated with the estimate: 80%; the middle value lies beyond the limit too.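

No step can be read between compound 4 and compound 1, compound 2 or compound 3 in this assay, as all four are reported only as limits: the limit of > 52000 nM in this assay, at which 4 of the 4 values shown sit. The compounds shown leave open whether any exchange on the shared core gives a measurable value in this assay, and how large it would be.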